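Methyl for fluoro on the fused aromatic ring

The source may hold more compounds than are shown below. What is called first, only, known or untested is meant among the compounds shown, and "the series" means these compounds.

Two compounds of this series carry numbers in a functional assay on the whole organism with Rattus norvegicus as the target, at a dose of 20 mg/kg by the oral route; on this read-out lower numbers stand for less inhibition and higher numbers for more inhibition at the one dose given (going by the name of the read-out). Compound 1 `NC(=O)/C=C1\CCc2c(F)cccc21` gives 40%, and compound 2 `NC(=O)/C=C1\CCc2cc(Cl)ccc21` gives 30%. On these two numbers compound 1 stands highest, but its distance to compound 2 lies within the usual scatter of repeated runs of this read-out, so the two cannot be put in order. Within the data shown here, no pair of measured compounds differs in only one place, so no single measured step is at hand to lean on.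

Compound 3 `Cc1cccc2c1CC/C2=C\C(N)=O` has not yet been measured. It differs from compound 1 in one place: methyl in place of fluoro on an aromatic carbon. The exchange brings no ring, no net charge and no change in the count of donors or acceptors, and it sits on the aromatic carbon ortho to a fused ring.

Nothing in the measured pair speaks to this exchange, and the single-dose read-out is coarse. The expected step in this assay is therefore none beyond the scatter: a number 2 percentage points lower from compound 1 to compound 3 (within the scatter). For compound 3 the estimated number in this assay is 38%, with a range from 20% to 56%.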

Compound 3, a percentage reported as inhibition, in the whole organism at one dose (the size of the read-out at that dose, not a potency): 15%
Compound 3: the middle estimate sits 23 percentage points above what was measured, and the stated range ends above it.
By their numbers in this assay, from the lowest: compound 3; then compounds 2 and 1 (each within the scatter of the next).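

In this assay, the aromatic carbon ortho to a fused ring proves sensitive to its substituent: methyl in place of fluoro gives a number 25 percentage points lower from compound 1 to compound 3 (beyond the scatter). Among these compounds, this is the first single-place step available, and it shows that exchanging one heavy atom for another can move this single-dose read-out, with no change in rings, net charge, donors or acceptors. No measured information bears on why the two groups differ.

On these data alone, whether the step reflects the loss of fluoro or the arrival of methyl remains open, and hydrogen, chloro, methoxy or trifluoromethyl on the same aromatic carbon would help separate these two readings. As far as these compounds go, it is also open whether the same exchange would give a similar step elsewhere on the aromatic ring, and how a carboxylic acid or a methyl amide in place of the amide would behave with fluoro or methyl at this position.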